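Vinyl for methyl on an amide carbonyl

The source may hold more compounds than are shown below. What is called first, only, known or untested is meant among the compounds shown, and "the series" means these compounds.

Of the compounds shown here, two from this set have been tested in a functional assay on BGC-823 cells (Homo sapiens) for inhibition, read by MTT assay, with a stated time of 72 h; on this read-out higher numbers stand for weaker inhibition and lower numbers for stronger inhibition. Compound 1, with the structure `CC(=O)Nc1cccc(C(=O)/C=C2/C(=O)Nc3ccccc32)c1`, gives 9100 nM in this assay. Compound 2, with the structure `O=C1Nc2ccccc2/C1=C\C(=O)c1ccccc1F`, gives 11800 nM in this assay. Compound 1 stands at one end of this pair, yet its gap to compound 2 lies within the usual scatter of repeated measurements, so the two numbers cannot be separated and neither compound can be called the stronger inhibitor.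

Compound 3, with the structure `C=CC(=O)Nc1cccc(C(=O)/C=C2/C(=O)Nc3ccccc32)c1`, has not yet been measured. It differs from compound 1 in one place: vinyl in place of methyl on a carbonyl carbon. Going by the values given here, no measured pair in this set shows what such a change does, so the expectation rests on compound 1 alone. The step from compound 1 to compound 3 is expected to be small, a 1.1-fold lower number from compound 1 to compound 3 (0.06 log units; within the scatter), not beyond the scatter in either direction. Compound 3 is therefore estimated to give about 8000 nM in this assay, with a plausible range from 3000 nM to 25000 nM.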

Compound 3, half-maximal inhibitory concentration: 3600 nM
Compound 3: middle estimate off by 2.2-fold (0.35 log units), on the high side; low and high end bracket the measured number.
By their numbers in this assay, from the lowest: compound 3; then compounds 1 and 2 (each within the scatter of the next).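

In this assay, going by these compounds alone, putting vinyl in place of methyl on a carbonyl carbon whose other neighbour is an amide-type nitrogen gives a 2.5-fold lower number from compound 1 to compound 3 (0.40 log units; beyond the scatter) and so provides the first step beyond the scatter in this set. Although modest, this step shows that the read-out responds to a change at this position, even though the swap leaves the counts of hydrogen-bond donors and acceptors and the net charge as they were. Nothing measured here bears on the reason for the step.

A single pair cannot separate the effect of the double bond from that of the added carbon, and an ethyl group on the same carbonyl carbon would be the natural test of the two. The compounds shown also leave open how a longer chain or a vinyl group carrying an amine would compare with compound 3 on the same core in this assay and whether the step seen here would hold for such groups.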